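This account rests on a few compounds, and the source may have more. Where it says the series, first, only, none or still open, it means among the compounds named here.

Measured so far in an ADME assay on HepG2 cells (Homo sapiens) for cytotoxicity, read by luminescence, CellTiter-Glo and ATP content, with a stated time of 72 h; on this read-out higher numbers stand for an effect only at larger amounts of compound and lower numbers for an effect already at smaller amounts:
- compound 1 `CC(C)(C)c1ccc(Oc2ccc3c(NCCCNCc4ccco4)ccnc3c2)cc1`: 3100 nM
- compound 2 `COc1ccc(Oc2ccc3c(NCCCNCc4cc(F)ccc4OC)ccnc3c2)cc1`: 7000 nM
- compound 3 `COc1ccc(F)cc1CNCCCNc1ccnc2cc(Cc3ccc(F)cc3Cl)ccc12`: 2460 nM

Compound 1 gives the second highest of the three numbers; against compound 3 the gap lies within the scatter, against compound 2 it lies beyond it. Compound 4 `COc1cccc(Oc2ccc3c(NCCCNCc4ccco4)ccnc3c2)c1` differs from compound 1 by 3-methoxyphenyl in place of 4-(tert-butyl)phenyl on an oxygen on an aromatic ring. Among the measured compounds shown here, the one step recorded, a 2.8-fold lower number from compound 2 to compound 3 (0.45 log units; beyond the scatter), replaces a 4-methoxyphenoxy by a benzyl group and does not touch the change made here. For the measured compounds named here, compound 2, which carries a methoxy on its phenoxy ring, gives the highest number, but it also differs in the amine side chain, so no step to compound 1 can be drawn. A small step, if any, is expected for compound 4, estimated as a 1.3-fold higher number from compound 1 to compound 4 (0.11 log units; within the scatter), giving 4000 nM with a range of 1500 nM to 10000 nM in this assay.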

Compound 4, half-maximal effective concentration: 15500 nM
Beside the measured number, compound 4's estimate is 3.9-fold (0.59 log units) below it, and the stated range ends below it.
By their numbers in this assay, from the lowest: compounds 3 and 1 (each within the scatter of the next); then compound 2; then compound 4.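

At the aromatic ring's oxygen, the group carried is not neutral in this assay: 3-methoxyphenyl in place of 4-(tert-butyl)phenyl gives a 5.0-fold higher number from compound 1 to compound 4 (0.70 log units; beyond the scatter), so with the rest of the molecule unchanged, the effect appears only at larger amounts of compound. This is the only step shown at this place. Nothing at hand accounts for its size.

The step swaps both the group and its ring location, so the two contributions cannot be separated. Going by these compounds, how a plain phenyl or a 3-(tert-butyl)phenyl on that oxygen would read remains open.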